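Adding an ethyl group to compound 1: expected microsomal half-life

This account rests on a few compounds, and the source may have more. Where it says the series, first, only, none or still open, it means among the compounds named here.

Among the measured compounds shown here, compound 1 `CCc1nc(NC(CC)CC)cnc1-c1ccc(Cl)cc1Cl` gives 0.467 h in an in vitro ADME assay on microsomes (Homo sapiens) for metabolic stability (on this read-out lower numbers stand for a shorter-lived compound and higher numbers for a longer-lived compound), the highest of the three numbers known. Compound 2 `CCc1nc(-c2ccc(OC)cc2O)c(CC)nc1NC(CC)CC` gives 0.3 h in this assay, within the scatter of compound 1, while compound 3 `CCc1nc(-c2ccc(C)cc2OC)c(CC)nc1NC(CC)CC` gives 0.183 h, beyond the scatter below compound 1. Compound 4 `CCc1nc(-c2ccc(Cl)cc2Cl)c(CC)nc1NC(CC)CC` has not been measured; it differs from compound 1 by ethyl in place of hydrogen on an aromatic carbon. Compounds 2 and 3, which resemble compound 4 more closely in their core substitution, both sit at or below compound 1, so a small step down, within the scatter, is expected for a 1.6-fold lower number from compound 1 to compound 4 (0.19 log units; within the scatter). Compound 4 is therefore estimated at 0.3 h, with a plausible range from 0.15 h to 0.6 h.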

Compound 4, half-life: 0.283 h
Estimate against measurement, compound 4: 1.1-fold (0.03 log units) above; measured number inside the range.
By their numbers in this assay, from the lowest: compounds 3, 4, 2 and 1 (each within the scatter of the next, the first and the last beyond it).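

In this assay, ethyl in place of hydrogen on this aromatic carbon, ortho to the (pentan-3-yl)amino group, gives a 1.7-fold lower number from compound 1 to compound 4 (0.22 log units; within the scatter). Among the compounds shown here, this is the first comparison in which only this position changes, and with the 2,4-dichlorophenyl group held constant, the ethyl group leaves the half-life within the scatter of the hydrogen compound. Nothing available explains this result.

The compounds shown leave open whether a methyl group, a longer chain or an amine on this carbon would also stay within the scatter of compound 1. They also leave open whether the ethyl step would be similar with another group in place of the 2,4-dichlorophenyl group.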